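This account rests on a few compounds, and the source may have more. Where it says the series, first, only, none or still open, it means among the compounds named here.

Measured compounds:
compound 1 `CN(C)/N=N/c1cccc(C(N)=O)c1`: 3.8
compound 2 `COC(=O)c1cccc(/N=N/N(C)C)c1`: 3.42

In a functional assay on L1210 cells (Mus musculus) for antiproliferative activity (on this read-out lower numbers stand for lower potency and higher numbers for higher potency (the scale is a negative logarithm)), compound 2 stands lowest of the two numbers, the nearest being compound 1, measured by a number 0.38 log units lower from compound 1 to compound 2 (beyond the scatter). Compound 3 `Cc1cccc(/N=N/N(C)C)c1` is not yet measured. The change from compound 2 is methyl in place of methoxycarbonyl on an aromatic carbon. Among the compounds with values here, the one measured step bears only loosely on it: it shows the carbonyl-bearing group being altered at the same place, with a modest drop. Nothing tells what removing the whole group does. A small step in either direction, within the scatter, is expected. Compound 3 is estimated at 3.5 with a range of 3 to 4. The expected step is a number 0.08 log units higher from compound 2 to compound 3 (within the scatter).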

Compound 3, logarithm of the reciprocal of the active concentration, log(1/C): 3.4
Beside the measured number, compound 3's estimate is 0.10 log units above it; the measured number falls inside the stated range.
By their numbers in this assay, from the lowest: compounds 3 and 2 (each within the scatter of the next); then compound 1.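

In this assay, replacing the whole methoxycarbonyl group with methyl gives a number 0.02 log units lower from compound 2 to compound 3 (within the scatter) and so leaves the read-out unmoved at this aromatic carbon. Replacing carbamoyl with methyl gives a number 0.40 log units lower from compound 1 to compound 3 (beyond the scatter) and matches the earlier step from carbamoyl to the ester, so among these three groups only carbamoyl stands apart. No available evidence explains this result.

From the compounds shown here alone, whether a carboxylic acid, an amine or a longer chain at this aromatic carbon would group with carbamoyl or with methyl remains open. Within the data shown here, only one carbonyl-free group appears here, so what sets carbamoyl apart also remains open.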